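A few compounds are considered here, and "the series" means these few. Any claim that something is new, unique, unknown or untested is made for them only; others in the source may bear on it.

Measured in a functional assay on the whole organism with Mus musculus as the target; a lower number here means that less compound is needed, a higher number that more compound is needed for the effect:
Compound 1 `O=Cc1cccn1Nc1ccncc1`: > 20 mg/kg, a limit
Compound 2 `CN(c1ccncc1)n1cccc1C=O`: > 20 mg/kg, a limit
Compound 3 `CCCN(c1ccncc1)n1cccc1C=O`: > 20 mg/kg, a limit

Compound 2 has no exact number, only the limit > 20 mg/kg. Going by the values given here, the series so far shows (the limit of > 20 mg/kg in this assay, at which 3 of the 3 values shown sit). Compound 4 `C=Cc1cccn1N(C)c1ccncc1` carries one change from compound 2: vinyl in place of formyl on an aromatic carbon. The measured steps are a step that the two limits leave unreadable from compound 1 to compound 2, a step that the two limits leave unreadable from compound 1 to compound 3 and a step that the two limits leave unreadable from compound 2 to compound 3. None of them touches the formyl, and none has a readable size, so no size or direction can be carried over. The expected change is a step that the limit leaves unreadable from compound 2 to compound 4, and this is a loose estimate. The estimate for compound 4 is 25 mg/kg, with an expected range from 10 mg/kg to 60 mg/kg.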

Compound 4, dose for half-maximal effect: 8.3 mg/kg
For compound 4 the middle estimate is 3.0-fold (0.48 log units) above the measured one; the measured number lies below the stated range.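

In this assay, going by these compounds alone, vinyl in place of formyl on this aromatic carbon gives an at least 2.4-fold lower number from compound 2 to compound 4 (0.38 log units; beyond the scatter), while the earlier steps, all made on the nitrogen, cannot be read. Within the data shown here, this is the first sign that the series can respond to a change, and it comes from this carbon, where a group with no hydrogen-bond acceptor replaces one that has one. Only compound 4 has left the value that holds the rest of the series: the limit of > 20 mg/kg in this assay, at which 3 of the 4 values shown sit.

From the compounds shown here alone, whether vinyl would have the same effect with the hydrogen of compound 1 or the propyl of compound 3 on that nitrogen remains open. So does the outcome with an ethyl, a longer chain or a carboxylic acid on this carbon.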